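The source may report more compounds than this note shows. Statements on the series, on what has been measured and on what is new or still open speak of the compounds shown alone.

Measured so far:
compound 1, `CCC(=O)Nc1c(C(O)(C(F)(F)F)C(F)(F)F)ccc2ccccc12`, in an assay on LtK cells with ATP-sensitive inward rectifier potassium channel 11 (Homo sapiens) as the target (a higher number here means that more compound is needed for the effect, a lower number that less compound is needed), gives 15 nM;
compound 2, `CCCC(=O)Nc1c(C(O)(C(F)(F)F)C(F)(F)F)ccc2ccccc12`, in this assay gives 131 nM;
compound 3, `O=C(Nc1c(C(O)(C(F)(F)F)C(F)(F)F)ccc2ccccc12)C1CC1`, in this assay gives 751 nM.

Compound 3 thus stands highest of the three, with a 5.7-fold higher number from compound 2 to compound 3 (0.76 log units; beyond the scatter) and a 50-fold higher number from compound 1 to compound 3 (1.70 log units; beyond the scatter). Compound 4, `O=C(Nc1ccc(Cl)cc1)Nc1c(C(O)(C(F)(F)F)C(F)(F)F)ccc2ccccc12`, carries (4-chlorophenyl)amino in place of cyclopropyl on a carbonyl carbon. For the measured compounds named here, the steps that bear on it all change the group on that carbonyl carbon: an 8.7-fold higher number from compound 1 to compound 2 (0.94 log units; beyond the scatter), a 50-fold higher number from compound 1 to compound 3 (1.70 log units; beyond the scatter) and a 5.7-fold higher number from compound 2 to compound 3 (0.76 log units; beyond the scatter), each raising the number as the group grew. Going by the values given here, no measured step exchanges an alkyl group for an arylamino group, so the direction is uncertain. Compound 4 is estimated at 1000 nM, between 100 nM and 10000 nM, an expected step of a 1.3-fold higher number from compound 3 to compound 4 (0.12 log units; within the scatter) that may well lie within the scatter.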

Compound 4, half-maximal effective concentration: 276 nM
Estimate against measurement, compound 4: 3.6-fold (0.56 log units) above; the measured number falls inside the stated range.
By their numbers in this assay, from the lowest: compound 1; then compound 2; then compound 4; then compound 3.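

Replacing cyclopropyl with the larger (4-chlorophenyl)amino on the carbonyl carbon brings [ a 2.7-fold lower number from compound 3 to compound 4 (0.43 log units; beyond the scatter) ], so compound 4 goes against the rise seen from ethyl to propyl and cyclopropyl. The arylamino group still does not match ethyl or propyl, with [ an 18-fold higher number from compound 1 to compound 4 (1.26 log units; beyond the scatter) ] and [ a 2.1-fold higher number from compound 2 to compound 4 (0.32 log units; beyond the scatter) ], the latter only just beyond the scatter. No measured evidence accounts for these shifts.

Going by these compounds, whether the chlorine or the nitrogen on the carbonyl carbon drives the change stays open. A plain phenyl or phenylamino group could separate the two.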